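Replacing a Sulfonate Ester with a Diamine Side Chain

The source may hold more compounds than are shown below. What is called first, only, known or untested is meant among the compounds shown, and "the series" means these compounds.

Compound 1 `CS(=O)(=O)Oc1c(C(=O)NCc2ccc(F)cc2)nc(Br)c2cccnc12` carries a (methylsulfonyl)oxy group on an aromatic carbon of its shared core. In a functional assay on MCF7 cells (Homo sapiens) for cytotoxicity, read by MTT assay, with a stated time of 72 h (on this read-out lower numbers stand for stronger inhibition and higher numbers for weaker inhibition), compound 1 gives "not determined" (no result reported), so it stands nowhere on the numbers shown here. Two related compounds do have values. Compound 2 `Nc1cccc(Nc2c(C(=O)NCc3ccc(F)cc3)nc(Br)c3cccnc23)c1` bears an aminophenyl-amino group and gives 8000 nM in this assay. Compound 3 `N[C@H]1CC[C@H](Nc2c(C(=O)NCc3ccc(Oc4ccccc4)cc3)nc(Br)c3cccnc23)CC1` bears a (4-aminocyclohexyl)amino group together with a phenoxy-substituted benzylamide and gives 7900 nM in this assay; these two values lie within the usual scatter of each other. Compound 4 `N[C@H]1CC[C@H](Nc2c(C(=O)NCc3ccc(F)cc3)nc(Br)c3cccnc23)CC1` differs from compound 1 in one place: (4-aminocyclohexyl)amino in place of (methylsulfonyl)oxy on an aromatic carbon. For the measured compounds named here, no measured pair shows this exact change, so no step size can be computed; the two neighbours with amino side chains both sit in the same low-micromolar region, and compound 4 is expected to land there as well. The estimate for compound 4 in this assay is 8000 nM, with a range from 3000 nM to 20000 nM.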

Compound 4, half-maximal inhibitory concentration: 2000 nM
For compound 4 the middle estimate is 4.0-fold (0.60 log units) above the measured one, and the stated range ends above it.
By their numbers in this assay, from the lowest: compound 4; then compounds 3 and 2 (each within the scatter of the next).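

Within this assay, the side chain on this position matters: with the fluoro-substituted benzylamide kept, 4-aminocyclohexyl in place of 3-aminophenyl on the nitrogen gives a 4.0-fold lower number from compound 2 to compound 4 (0.60 log units; beyond the scatter). The far end of the molecule counts as well: with the (4-aminocyclohexyl)amino group kept, fluoro in place of phenoxy on an aromatic carbon gives a 4.0-fold lower number from compound 3 to compound 4 (0.60 log units; beyond the scatter). The change away from (methylsulfonyl)oxy itself cannot be read, as compound 1 has no number, and nothing shown here accounts for either step.

As far as these compounds go, it remains open whether the ring of the 4-aminocyclohexyl group is needed, or whether an open chain such as 2-aminoethyl on the same nitrogen would give a similar number. A chloro group in place of fluoro on the benzylamide is also untested by these compounds.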